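This account rests on a few compounds, and the source may have more. Where it says the series, first, only, none or still open, it means among the compounds named here.

Within the data shown here, compound 2 `CC(C)n1nc(-c2ccnc3[nH]c(C4CCN(CC(=O)N(C)C)CC4)cc23)ccc1=O` gives 13 uL/min in an ADME assay on microsomes from liver (Homo sapiens) for metabolic stability (a lower number here means slower removal, a higher number faster removal of the compound), the only plain number among the three measured compounds. Compound 1 `CN(C)C(=O)CN1CCC(c2cc3c(-c4ccc(=O)n(C5CCC5)c4)ccnc3[nH]2)CC1` sits at the limit of the assay, < 3 uL/min. Compound 3 `CC(=O)N1CCC(c2cc3c(-c4ccc(=O)n(C(C)C)c4)ccnc3[nH]2)CC1` likewise returns the limit, < 3 uL/min. Compound 2 therefore stands alone with a number, while the limit of < 3 uL/min in this assay, at which 2 of the 3 values shown sit, covers the other two. Compound 4 `CC(C)n1cc(-c2ccnc3[nH]c(C4CCN(CC(=O)N(C)C)CC4)cc23)ccc1=O` differs from compound 2 by a group of 10 heavy atoms (8 carbon, 1 nitrogen, 1 oxygen; one six-membered aromatic ring with 1 hetero atom) in place of a group of 10 heavy atoms (7 carbon, 2 nitrogen, 1 oxygen; one six-membered aromatic ring with 2 hetero atoms), on an aromatic carbon. Compound 3 carries that same entering group on the shared core and stays at the limit. Because of the limit of < 3 uL/min in this assay, at which 2 of the 3 values shown sit, the step expected in this assay is a 2.6-fold lower number from compound 2 to compound 4 (0.41 log units; beyond the scatter), downward and beyond the usual scatter. Compound 4 is accordingly estimated at 5 uL/min, within 3 uL/min to 11 uL/min, with a fair chance that only the limit is reported.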

Compound 4, intrinsic clearance in a liver preparation (reported as CLH), per the amount of preparation that the assay uses: < 3 uL/min
Compound 4 gave a limit, no number; the forecaster's own chance of this, stated with the estimate: 40%; middle value at least 1.6-fold (0.22 log units) away from the limit.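

In this assay, putting the ring with 1 hetero atom in place of the ring with 2 hetero atoms, on an aromatic carbon opposite the ring nitrogen, gives an at least 4.3-fold lower number from compound 2 to compound 4 (0.63 log units; beyond the scatter), so this one change at this position is enough to move the number beyond the scatter. The steps to compound 4 from compound 1 and from compound 3 cannot be read. Compound 4 returns a limit, not a number, so the step has no upper size: the limit of < 3 uL/min in this assay, at which 3 of the 4 values shown sit.

Going by these compounds, how far the number would fall remains open. So does whether a fluorine or an amine on the entering ring would keep it there.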